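This account rests on a few compounds, and the source may have more. Where it says the series, first, only, none or still open, it means among the compounds named here.

Measured in a functional assay on P388 cells (Mus musculus) for antiproliferative activity; a higher number here means a weaker inhibitor, a lower number a stronger inhibitor:
- compound 1 `Cc1ccc(S(=O)(=O)Nc2cccc3cc[nH]c23)cc1`: 4.3 ug/mL
- compound 2 `N#Cc1ccc(S(=O)(=O)Nc2cccc3cc[nH]c23)cc1`: 4.2 ug/mL
- compound 3 `Nc1ccc(S(=O)(=O)Nc2cccc3cc[nH]c23)cc1`: 14 ug/mL

Compound 2 and compound 1 share the low end of these numbers, and compound 3 sits above both. Exchanging the group on one aromatic carbon gave a 1.0-fold lower number from compound 1 to compound 2 (0.01 log units; within the scatter) with cyano in place of methyl, a 3.3-fold higher number from compound 2 to compound 3 (0.52 log units; beyond the scatter) with amino in place of cyano, and a 3.3-fold higher number from compound 1 to compound 3 (0.51 log units; beyond the scatter) with amino in place of methyl.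

The next compound, compound 4 `N#Cc1ccc(S(=O)(=O)Nc2cccc3c(C#N)c[nH]c23)cc1`, keeps all of compound 2 and adds one change: cyano in place of hydrogen on an aromatic carbon. This is cyano in place of hydrogen on an aromatic carbon, two ring bonds from the ring nitrogen.

Going by the values given here, none of the measured steps touches that carbon, so they serve only as a rough guide to size. This suggests a modest step at most. The direction is not fixed by the data, and only a weak lean toward a lower number seems fair, given a 1.0-fold lower number from compound 1 to compound 2 (0.01 log units; within the scatter). The expected change is a 2.1-fold lower number from compound 2 to compound 4 (0.32 log units; beyond the scatter). For compound 4 the estimated value is 2 ug/mL, with an expected range of 0.4 ug/mL to 8 ug/mL.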

Compound 4, half-maximal inhibitory concentration: 0.53 ug/mL
Compound 4: the middle estimate sits 3.8-fold (0.58 log units) above what was measured, and the stated range covers the measured number.
By their numbers in this assay, from the lowest: compound 4; then compounds 2 and 1 (each within the scatter of the next); then compound 3.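

In this assay, this carbon of the five-membered aromatic ring, two ring bonds from the ring nitrogen, carries hydrogen in compounds 1 to 3, so those compounds could not show whether a change here matters. Placing cyano here gives a 7.9-fold lower number from compound 2 to compound 4 (0.90 log units; beyond the scatter), the largest step in the series and the first sign that this position affects the antiproliferative read-out. The same group elsewhere behaved differently: exchanging methyl for cyano at the other changed carbon gave a 1.0-fold lower number from compound 1 to compound 2 (0.01 log units; within the scatter), so cyano's effect here cannot be predicted from that earlier exchange.

On these data alone, whether a smaller group such as chloro, or an amine or a carboxylic acid, would have a similar effect at this carbon remains open, as does whether the step would persist with methyl or amino in place of the other cyano. No available measurement explains why the number falls at this position.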